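Leucyl-tRNA synthetase acylsulfonamides: removing the pyrimidine methyl

A few compounds are considered here, and "the series" means these few. Any claim that something is new, unique, unknown or untested is made for them only; others in the source may bear on it.

For the measured compounds named here, compound 2 `Cc1cc(-c2cccc(S(=O)(=O)NC(=O)[C@@H](N)CC(C)C)c2)nc(N)n1` gives 160 nM in an assay on isolated protein for inhibition of leucine--tRNA ligase, cytoplasmic (Homo sapiens) (a higher number here means a weaker inhibitor, a lower number a stronger inhibitor), the lowest of the two numbers so far. The nearest is compound 1 `CC(C)C[C@H](N)C(=O)NS(=O)(=O)c1cccc(-c2cccc(N)n2)c1`, which in this assay gives 850 nM; the step of a 5.3-fold lower number from compound 1 to compound 2 (0.73 log units; beyond the scatter) came with 2-amino-6-methylpyrimidin-4-yl in place of 6-aminopyridin-2-yl on an aromatic carbon. Compound 3 `CC(C)C[C@H](N)C(=O)NS(=O)(=O)c1cccc(-c2ccnc(N)n2)c1` differs from compound 2 by hydrogen in place of methyl on an aromatic carbon, read one bond further out as 2-amino-6-methylpyrimidin-4-yl to 2-aminopyrimidin-4-yl. Going by the values given here, no measured step isolates this methyl: the only step on record changes ring and substituents together, so it bears on the present change only loosely. A small loss beyond the scatter, or none, is the working expectation in this assay. Compound 3 is therefore expected to give about 320 nM, within 120 nM to 900 nM, a step of a 2.0-fold higher number from compound 2 to compound 3 (0.30 log units; within the scatter).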

Compound 3, half-maximal inhibitory concentration: 3900 nM
Estimate against measurement, compound 3: 12-fold (1.09 log units) below, and the stated range ends below it.
By their numbers in this assay, from the lowest: compound 2; then compound 1; then compound 3.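

In this assay, the methyl on this aromatic carbon, next to the ring nitrogen, proves to be a large term on its own: a single carbon separates the pair (a 24-fold higher number from compound 2 to compound 3 (1.39 log units; beyond the scatter)). For the compounds shown here, the ring change alone does not hold the earlier gain: with hydrogen at this carbon, 2-aminopyrimidin-4-yl falls behind 6-aminopyridin-2-yl (a 4.6-fold higher number from compound 1 to compound 3 (0.66 log units; beyond the scatter)), so the advantage of compound 2 over compound 1 is seen only with the methyl present. Nothing available accounts for the size of these steps. Going by these compounds, whether ethyl, trifluoromethyl or methoxy at this carbon would match or improve on methyl remains open. Also open, on these data alone, is whether a methyl carries the same weight on the 6-aminopyridin-2-yl ring of compound 1.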